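A few compounds are considered here, and "the series" means these few. Any claim that something is new, unique, unknown or untested is made for them only; others in the source may bear on it.

Compound 1 `Cc1nc(N)c2nc(-c3ccccc3)sc2n1` carries a methyl group on the shared core. In a functional assay on CHO cells for antagonist activity at adenosine receptor A2b (Homo sapiens), read by cAMP accumulation, with a stated time of 10 min (a higher number here means a weaker inhibitor, a lower number a stronger inhibitor), compound 1 gives only a limit, > 30000 nM. Compound 2 `Nc1nc(-c2ccc(CO)cc2)nc2sc(-c3ccccc3)nc12` carries 4-(hydroxymethyl)phenyl in its place. In this assay compound 2 likewise gives only a limit, > 30000 nM. The step that the two limits leave unreadable from compound 1 to compound 2 cannot be read because of the limit of > 30000 nM in this assay, at which 2 of the 2 values shown sit. Compound 3 `COc1cccc(-c2nc(N)c3nc(-c4ccccc4)sc3n2)c1` differs from compound 2 by 3-methoxyphenyl in place of 4-(hydroxymethyl)phenyl on an aromatic carbon. Among the measured compounds shown here, no measured step bears on this change, and both known values sit at the limit, so no direction can be drawn. Compound 3 is expected to remain weak, with an estimated at least 1.5-fold lower number from compound 2 to compound 3 (0.17 log units; that floor lies within the scatter) and an estimated value of 20000 nM, between 3000 nM and 60000 nM.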

Compound 3, half-maximal inhibitory concentration: > 30000 nM
Compound 3 ended at the assay's limit; the forecaster's own chance of this, stated with the estimate: 60%; at least 1.5-fold (0.17 log units) between middle value and limit.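

Among the compounds shown here, no step among compound 1, compound 2 and compound 3 can be read in this assay, because each gives only a limit: the limit of > 30000 nM in this assay, at which 3 of the 3 values shown sit. As far as these compounds go, how methyl, 4-(hydroxymethyl)phenyl and 3-methoxyphenyl rank against one another stays open.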